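This account rests on a few compounds, and the source may have more. Where it says the series, first, only, none or still open, it means among the compounds named here.

Of the compounds shown here, three sharing one core have been tested in a functional assay on HeLa cells (Homo sapiens) for antiproliferative activity, read by MTT assay, with a stated time of 48 h; a lower number here means a stronger inhibitor, a higher number a weaker inhibitor. Compound 1 `COc1ccc2[nH]c(-c3cn(-c4ccccc4)nc3-c3ccc(F)cc3)nc2c1` gives 7510 nM in this assay. Compound 2 `Fc1ccc(-c2nn(-c3ccccc3)cc2-c2nc3cc(C(F)(F)F)ccc3[nH]2)cc1` gives 3520 nM, and compound 3 `COc1ccc2[nH]c(-c3cn(-c4ccccc4)nc3-c3ccc(Cl)cc3)nc2c1` gives 3630 nM. The two changes recorded so far are modest. Replacing methoxy with trifluoromethyl, (trifluoromethyl in place of methoxy on an aromatic carbon), gave a 2.1-fold lower number from compound 1 to compound 2 (0.33 log units; beyond the scatter). Replacing fluoro with chloro, (chloro in place of fluoro on an aromatic carbon), gave a 2.1-fold lower number from compound 1 to compound 3 (0.32 log units; beyond the scatter). Compound 2 and compound 3 lie within the scatter of each other, so nothing separates them.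

Compound 4 `FC(F)(F)c1ccc2[nH]c(-c3cn(-c4ccccc4)nc3-c3ccc(Cl)cc3)nc2c1` has not yet been measured in this assay. It carries the trifluoromethyl group of compound 2 together with the chloro group of compound 3. Set against compound 3, the difference is trifluoromethyl in place of methoxy on an aromatic carbon; this is the same change that was made from compound 1 to compound 2, at the same place on the fused ring system, and the only way the two pairs differ from each other is the one counted as chloro in place of fluoro on an aromatic carbon, where chloro stands in for fluoro in compound 3 and compound 4.

Since the earlier trifluoromethyl step gave a 2.1-fold lower number from compound 1 to compound 2 (0.33 log units; beyond the scatter), and since chloro in compound 3 gave a 2.1-fold lower number from compound 1 to compound 3 (0.32 log units; beyond the scatter) on its own, compound 4 is expected to show a step of about a 2.0-fold lower number from compound 3 to compound 4 (0.30 log units; within the scatter) from compound 3 in this assay. On that basis compound 4 is estimated at 1800 nM in this assay, with a plausible span from 800 nM to 4000 nM.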

Compound 4, half-maximal inhibitory concentration: 4420 nM
Beside the measured number, compound 4's estimate is 2.5-fold (0.39 log units) below it; the measured number lies above the stated range.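

In this assay, trifluoromethyl in place of methoxy gave a 1.2-fold higher number from compound 3 to compound 4 (0.09 log units; within the scatter), and chloro in place of fluoro gave a 1.3-fold higher number from compound 2 to compound 4 (0.10 log units; within the scatter), so neither step on this second core lies beyond the scatter. Set beside the earlier trifluoromethyl step, this result does not establish that the change behaves differently from one core to another, nor does it show that the change carries over unaltered: the same change on two cores in this assay, a 2.1-fold lower number (0.33 log units; beyond the scatter) from compound 1 to compound 2 and a 1.2-fold higher number (0.09 log units; within the scatter) from compound 3 to compound 4, 2.6-fold (0.41 log units) apart, within the scatter of two such steps The same holds for the chloro change, so these compounds neither show that the two changes add up nor show that they fail to: the same change on two cores in this assay, a 2.1-fold lower number (0.32 log units; beyond the scatter) from compound 1 to compound 3 and a 1.3-fold higher number (0.10 log units; within the scatter) from compound 2 to compound 4, 2.6-fold (0.41 log units) apart, within the scatter of two such steps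

The compounds shown carry only methoxy or trifluoromethyl on the fused system and only fluoro or chloro at the other changed place, so it stays open how an amine, a carboxylic acid or a longer chain at either place would read in this assay. From the compounds shown here alone, with so few pairs behind each change, it also stays open whether either change would give a step beyond the scatter on a core bearing, for example, a bromo or a methyl group.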